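A few compounds are considered here, and "the series" means these few. Any claim that something is new, unique, unknown or untested is made for them only; others in the source may bear on it.

In an assay on microsomes from liver for inhibition of sterol O-acyltransferase 1 (Rattus norvegicus) (on this read-out higher numbers stand for weaker inhibition and lower numbers for stronger inhibition), the three measured compounds gave these values:

Compound 1, `CCCCCCCCCCCCn1nnc(C(NC(=O)c2ccccc2C(F)(F)F)c2ccccc2)n1`: 120 nM
Compound 2, `CCCCCCCCCCCCn1nnnc1C(NC(=O)c1ccc(F)cc1F)c1ccccc1`: 380 nM
Compound 3, `CCCCCCCCCCCCn1nnnc1C(NC(=O)c1cccc([N+](=O)[O-])c1)c1ccccc1`: 190 nM

On these numbers compound 3 stands second highest of the three, but its gap to compound 1 and its gap to compound 2 both lie within the usual scatter, so no ordering among the three is secure. Compound 4, `CCCCCCCCCCCCn1nnnc1C(NC(=O)c1ccnc(SC)c1)c1ccccc1`, is the compound not yet measured. It differs from compound 3 in one place: a group of 8 heavy atoms (6 carbon, 1 nitrogen, 1 sulfur; one six-membered aromatic ring with 1 hetero atom) in place of a group of 9 heavy atoms (6 carbon, 1 nitrogen, 2 oxygen; one six-membered aromatic ring of carbon only), on a carbonyl carbon. Within the data shown here, only one measured step bears on this kind of change, the exchange of the aromatic group on the same carbonyl carbon from compound 2 to compound 3, which gave a 2.0-fold lower number from compound 2 to compound 3 (0.30 log units; within the scatter). Among the measured compounds shown here, that step stayed within the scatter, and it is the only guide available; no measured compound carries a ring with a hetero atom or a sulfur at this place, so nothing more specific can be drawn from the data. The author therefore expects no step beyond the scatter, estimating a 1.1-fold higher number from compound 3 to compound 4 (0.02 log units; within the scatter) in this assay. Compound 4 is accordingly estimated at 200 nM, with a range from 80 nM to 500 nM.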

Compound 4, half-maximal inhibitory concentration: 140 nM
The estimate for compound 4 lay 1.4-fold (0.15 log units) above the measured number, and the stated range covers the measured number.
By their numbers in this assay, from the lowest: compounds 1, 4, 3 and 2 (each within the scatter of the next, the first and the last beyond it).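

In this assay, exchanging the 3-nitrophenyl for the six-membered aromatic ring with 1 hetero atom and its sulfur-bearing substituent gave a 1.4-fold lower number from compound 3 to compound 4 (0.13 log units; within the scatter), so at this place on a carbonyl carbon the two groups cannot be told apart, even though one ring is of carbon only and the other is not. Set against the 2,4-difluorophenyl, the same group gave a 2.7-fold lower number from compound 2 to compound 4 (0.43 log units; beyond the scatter), a modest step but the first among these amides with the same core to pass beyond the scatter, which shows that the aromatic group at this place can shift the number measurably, while compound 3 remains within the scatter of both neighbours. No independent measurement is available to explain this difference.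

The compounds shown do not separate the contribution of the ring's hetero atom from that of the sulfur-bearing substituent, as the two enter together in compound 4. Also open, as far as these compounds go, is how the number in this assay would respond to an amine or a carboxylic acid on the aromatic group at this place.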